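A few compounds are considered here, and "the series" means these few. Any claim that something is new, unique, unknown or untested is made for them only; others in the source may bear on it.

Measured compounds in a functional assay on A549 cells (Homo sapiens) for cytotoxicity, read by CCK-8 assay, with a stated time of 24 h; on this read-out lower numbers stand for stronger inhibition and higher numbers for weaker inhibition:
- compound 1, `C/C(=C\c1ccc(-c2ccc(C)cc2)o1)C(N)=O`, gives > 50000 nM, a limit of the assay.
- compound 2, `C/C(=C\c1cc(-c2ccc(F)cc2)cs1)C(N)=O`, gives > 50000 nM, a limit of the assay.
- compound 3, `C/C(=C\c1cccc(-c2ccc(C)cc2)c1)C(N)=O`, gives 5100 nM.

Compound 2 thus stands at the limit of > 50000 nM in this assay, at which 2 of the 3 values shown sit; only compound 3 returns a number in this assay. Compound 4, `COc1ccc(-c2csc(/C=C(\C)C(N)=O)c2)cc1`, differs from compound 2 by methoxy in place of fluoro on an aromatic carbon. Among the measured compounds shown here, no pair of measured compounds here carries this change, so its size cannot be read from the data. Compound 2 itself gives only a limit. For compound 4 the expected step, a step that the limit leaves unreadable from compound 2 to compound 4, is none beyond the scatter in this assay. Compound 4 is estimated at 60000 nM, expected between 15000 nM and 250000 nM, most likely again reported only as a limit.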

Compound 4, half-maximal inhibitory concentration: > 50000 nM
Compound 4: no number, only a limit; the forecaster's own chance of this, stated with the estimate: 75%; the middle value does not contradict the limit.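

Compound 2 and compound 4 both return only a limit, so no step can be read between them: the limit of > 50000 nM in this assay, at which 3 of the 4 values shown sit.

The compounds shown leave open whether methoxy in place of fluoro on an aromatic carbon shifts the read-out at all.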